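Ring-nitrogen chain swap: compound 2 to compound 4

The source may report more compounds than this note shows. Statements on the series, on what has been measured and on what is new or still open speak of the compounds shown alone.

Measured in an in vitro functional assay on HEK ts201 cells for antagonist activity at Neuronal acetylcholine receptor; alpha4/beta2 (Homo sapiens), read by fluorescence and calcium flux; on this read-out lower numbers stand for stronger inhibition and higher numbers for weaker inhibition:
compound 1, `O=C(OCC1CCCN(CCCc2ccccc2)C1)c1ccc(-c2ccccc2)cc1`, gives 6310 nM
compound 2, `CC1CC(=O)N(c2ccccc2C(=O)OCC2CCCN(CCCCCOc3ccccc3)C2)C1=O`, gives 17000 nM
compound 3, `O=C(CCC1CCCNC1)c1ccccc1-c1ccccc1`, gives 9120 nM

On these numbers compound 2 has the highest of the three. Compound 3 comes nearest, and its number lies within the scatter of that of compound 2, so no order is claimed between the two. Compound 1 stands furthest, beyond the scatter, with the lower number of the pair.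

Compound 4, `CC1CC(=O)N(c2ccccc2C(=O)OCC2CCCN(CCCC3CCCCC3)C2)C1=O`, awaits measurement. It differs from compound 2 by cyclohexyl in place of 2-phenoxyethyl on a saturated chain carbon, three bonds along the chain from an amine nitrogen in a ring. Among the compounds with values here, no two measured compounds differ in one place only, so no measured step guides this change. In this assay a small step toward a lower number is expected, not clearly beyond the scatter: a 1.4-fold lower number from compound 2 to compound 4 (0.15 log units; within the scatter). Compound 4 is estimated at 12000 nM, within 4000 nM to 40000 nM.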

Compound 4, half-maximal inhibitory concentration: 14500 nM
The estimate for compound 4 lay 1.2-fold (0.08 log units) below the measured number; measured number inside the range.
By their numbers in this assay, from the lowest: compounds 1, 3, 4 and 2 (each within the scatter of the next, the first and the last beyond it).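

In this assay the swap gives a 1.2-fold lower number from compound 2 to compound 4 (0.07 log units; within the scatter) and so, on a saturated chain carbon three bonds along the chain from an amine nitrogen in a ring, cyclohexyl and 2-phenoxyethyl cannot be told apart. On this core, the aromatic ring and the oxygen of 2-phenoxyethyl are therefore not required to keep the number within the scatter. No supporting data bear on this result. Still open, on these data alone, is whether a carboxylic acid or an amine at the chain end, or a shorter chain, would give a step beyond the scatter.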